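The source may report more compounds than this note shows. Statements on the series, on what has been measured and on what is new or still open speak of the compounds shown alone.

Measured so far:
- compound 1, `C=CCOc1ccc2c(=O)c(-c3cc(OC)c(OC)cc3OC)coc2c1`: 5100 nM
- compound 2, `COc1ccc2c(=O)c(-c3cc(OC)c(OC)cc3OC)coc2c1`: 5200 nM
- compound 3, `COc1cccc(C(=O)Oc2ccc3c(=O)c(-c4cc(OC)c(OC)cc4OC)coc3c2)c1`: > 10000 nM

In a functional assay on B16 cells (Mus musculus) for antiproliferative activity, read by MTT assay, with a stated time of 24 h (on this read-out higher numbers stand for weaker inhibition and lower numbers for stronger inhibition), compound 1 gives 5100 nM and compound 2 gives 5200 nM; the two agree, since a 1.0-fold higher number from compound 1 to compound 2 (0.01 log units; within the scatter). Compound 3 stands differently: its result is only a limit of the assay, > 10000 nM, so no exact number is known for it (the limit of > 10000 nM in this assay, at which 1 of the 3 values shown sits).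

The next step leads from compound 3 to compound 4, `COc1cc(OC)c(-c2coc3cc(OCc4ccc(Br)cc4)ccc3c2=O)cc1OC`. The change is 4-bromobenzyl in place of (3-methoxyphenyl)carbonyl on an oxygen on an aromatic ring. Within the data shown here, two measured steps bear on it, as both bring the (3-methoxyphenyl)carbonyl group of compound 3 in at that oxygen: an at least 1.9-fold higher number from compound 1 to compound 3 (0.29 log units; that floor lies within the scatter) and an at least 1.9-fold higher number from compound 2 to compound 3 (0.28 log units; that floor lies within the scatter). Compound 4 takes that group away again and carries, like compound 1 and compound 2, a carbon chain on the oxygen on the aromatic ring. The expected change is therefore a step back toward the values of those two compounds, that is, downward, and the estimated step is an at least 1.6-fold lower number from compound 3 to compound 4 (0.22 log units; that floor lies within the scatter). The limit for compound 3 leaves the size of that step uncertain. Compound 4 is estimated at 6000 nM, with a range from 2000 nM to 20000 nM.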

Compound 4, half-maximal inhibitory concentration: 1180 nM
The estimate for compound 4 lay 5.1-fold (0.71 log units) above the measured number, and the stated range ends above it.
By their numbers in this assay, from the lowest: compound 4; then compounds 1 and 2 (each within the scatter of the next). At a limit, above all of these: compound 3.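

In this assay, the oxygen on an aromatic ring now shows a change that reaches beyond the scatter, which the swap between allyl and methyl did not: a 4.4-fold lower number from compound 2 to compound 4 (0.64 log units; beyond the scatter), and a 4.3-fold lower number from compound 1 to compound 4 (0.64 log units; beyond the scatter). The 4-bromobenzyl group gives the lowest number of the four compounds, although it brings an aromatic ring just as the (3-methoxyphenyl)carbonyl group does, so an aromatic ring on this oxygen does not by itself weaken the compound. The third step, an at least 8.4-fold lower number from compound 3 to compound 4 (0.92 log units; beyond the scatter), gives only a floor and no exact size because the result for compound 3 is a limit: the limit of > 10000 nM in this assay, at which 1 of the 4 values shown sits.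

On these data alone, it remains open whether the bromine is needed, or whether a plain benzyl group would give a similar number. As far as these compounds go, how an amine on the chain at this oxygen would read also remains open.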